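The source may hold more compounds than are shown below. What is called first, only, known or untested is meant among the compounds shown, and "the series" means these compounds.

Compound 1 `O=C(CCCCC1CCSS1)NCc1cn(CCCOc2ccc3ccc(=O)oc3c2)nn1`: 39.2%
Compound 2 `CC(=O)c1cc2ccc(OCCCCCn3cc(CNC(=O)CCCCC4CCSS4)nn3)cc2oc1=O`: 22.2%

In a functional assay on PC-12 cells (Rattus norvegicus) for cytotoxicity, read by MTT assay, with stated times of 3 h and 2 h, tested at 5 uM (a lower number here means a weaker effect, a higher number a stronger effect of the compound at the concentration tested), compound 2 stands at the lower of the two numbers, and the gap to compound 1 is beyond the usual scatter. Compound 3 `COc1ccc(-c2cc3ccc(OCCCCCn4cc(CNC(=O)CCCCC5CCSS5)nn4)cc3oc2=O)cc1OC` is not yet measured. It differs from compound 2 in one place: 3,4-dimethoxyphenyl in place of acetyl on an aromatic carbon. Going by the values given here, no step between two measured compounds is available to show what a change of this kind does, so the expectation for compound 3 is held loosely. The step from compound 2 to compound 3 is expected to be small, a number 5.8 percentage points higher from compound 2 to compound 3 (within the scatter), with no clear direction beyond the scatter. Compound 3 is estimated at 28%, within a range from 12% to 46%.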

Compound 3, a percentage reported as activity, at one concentration (the size of the read-out at that concentration, not a potency): 46.9%
Beside the measured number, compound 3's estimate is 18.9 percentage points below it, outside the stated range (above it).
By their numbers in this assay, from the lowest: compound 2; then compounds 1 and 3 (each within the scatter of the next).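

Replacing acetyl with 3,4-dimethoxyphenyl on this aromatic carbon gives a number 24.7 percentage points higher from compound 2 to compound 3 (beyond the scatter) in this assay and so shows that a change at this one place can move the read-out. Compound 1 and compound 2 could not show this, as they differ in more than one place. Nothing measured here explains the step.

The compounds shown leave open whether the added ring or its two methoxy groups account for the step. A plain phenyl group on the same carbon would help separate the two.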